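Capping the free amine of an amino-amide with a tosyl group

The compounds below may be only part of what the source reports. "The series", "measured", "known", "first", "only" and "open" are said of these compounds alone.

Compound 1 `CCCCCCCCCCCCCCNC(=O)[C@@H](N)[C@@H](C)O` pairs a long saturated chain with a small amino-acid head carrying a free amine. In a functional assay on SW-620 cells (Homo sapiens) for cytotoxicity, read by MTT assay, with a stated time of 48 h (on this read-out higher numbers stand for weaker inhibition and lower numbers for stronger inhibition), compound 1 gives 18700 nM, the lowest of the three numbers measured here. Compound 2 `CCCCCCCCCCCCCCCCCCNC(=O)[C@@H](N)[C@@H](C)O` gives 21400 nM in this assay; the step of a 1.1-fold higher number from compound 1 to compound 2 (0.06 log units; within the scatter) is a chain change only. Compound 3 `CCCCCCCCCCCCNC(=O)[C@@H](NC(=O)c1ccccc1)[C@@H](C)O` gives 200000 nM in this assay; it differs from compound 1 in two places, a shorter chain and a benzoyl group on the amine, so the two values can only be set side by side.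

Compound 4 `CCCCCCCCCCCCCCNC(=O)[C@@H](NS(=O)(=O)c1ccc(C)cc1)[C@@H](C)O` changes compound 1 at the amine: (4-methylphenyl)sulfonyl in place of hydrogen on an amine nitrogen. For the measured compounds named here, no measured step covers this change alone. Going by the values given here, the only guide is compound 3, whose value of 200000 nM sits far above compound 1 once the amine is capped. A weakening step is therefore expected, an 8.0-fold higher number from compound 1 to compound 4 (0.90 log units; beyond the scatter). Compound 4 is estimated at 150000 nM, within 40000 nM to 400000 nM.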

Compound 4, half-maximal inhibitory concentration: 15200 nM
Compound 4: middle estimate off by 9.9-fold (0.99 log units), on the high side, and the stated range ends above it.
By their numbers in this assay, from the lowest: compounds 4, 1 and 2 (each within the scatter of the next); then compound 3.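

In this assay, putting (4-methylphenyl)sulfonyl on the amine nitrogen gives a 1.2-fold lower number from compound 1 to compound 4 (0.09 log units; within the scatter), so the free amine hydrogen of compound 1 is not needed to hold the number at this level, and this position accepts a group of 10 heavy atoms with one aromatic ring. Capping the amine therefore does not by itself bring a high number. Nothing available here explains why this exchange leaves the number within the scatter.

Still open, on these data alone, is what a benzoyl group would do on the amine of compound 1 with its chain unchanged. Also open, as far as these compounds go, is how a smaller cap, such as an acetyl or a methanesulfonyl group, would compare with the (4-methylphenyl)sulfonyl group of compound 4.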